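A few compounds are considered here, and "the series" means these few. Any claim that something is new, unique, unknown or untested is made for them only; others in the source may bear on it.

Measured so far:
compound 1, `Cc1ccc(-c2nn(-c3ccccc3)cc2C(=O)NOCc2ccccc2F)cc1`, 2110 nM in a functional assay on MCF7 cells (Homo sapiens) for antiproliferative activity, read by MTT assay, with a stated time of 48 h, in the presence of a further agent that is not named here; a higher number here means a weaker inhibitor of growth, a lower number a stronger inhibitor of growth;
compound 2, `COc1ccc(-c2nn(-c3ccccc3)cc2C(=O)NOCc2ccccc2)cc1`, 2770 nM in this assay.

Going by the values given here, the two compounds share the core and differ at two sites at once, so no single step between them can be read. In this assay compound 1 gives 2110 nM and compound 2 gives 2770 nM; the two numbers lie within the scatter of each other, and nothing further is to be read from the pair.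

Compound 3, `COc1ccc(-c2nn(-c3ccccc3)cc2C(=O)NOCc2ccccc2F)cc1`, is not yet measured. It differs from compound 2 in one place: fluoro in place of hydrogen on an aromatic carbon. The same change, taken alone, has not been tested anywhere in this pair, since compound 1 carries it together with a second difference at the other aromatic ring. What the two measured compounds show is that both carry the shared core and land close together in this assay regardless of the fluoro.

For compound 3 the expectation is therefore a number close to that of compound 2, with a step from compound 2 to compound 3 of a 1.2-fold lower number from compound 2 to compound 3 (0.06 log units; within the scatter), that is, none beyond the scatter. The estimate for compound 3 in this assay is 2400 nM, with a range from 1100 nM to 5200 nM.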

Compound 3, concentration for 50% growth inhibition: 6000 nM
Compound 3: middle estimate off by 2.5-fold (0.40 log units), on the low side, and the stated range ends below it.
By their numbers in this assay, from the lowest: compounds 1 and 2 (each within the scatter of the next); then compound 3.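

Fluoro in place of hydrogen can now be read alone: benzyl to 2-fluorobenzyl in this assay gives a 2.2-fold higher number from compound 2 to compound 3 (0.34 log units; beyond the scatter) and so this place on the benzyl group is not indifferent to the change, which compound 1 and compound 2 could not show. With the 2-fluorobenzyl group held fixed, methoxy in place of methyl on an aromatic carbon gives a 2.8-fold higher number from compound 1 to compound 3 (0.45 log units; beyond the scatter) and this step too lies beyond the scatter, though it is modest in size, as is the fluoro step. Each single change away from compound 3 thus lowers the number, so the closeness of compound 1 and compound 2 reflects two differences that offset each other, not a fluoro change without effect.

Going by these compounds alone, whether the fluoro step holds with methyl in place of methoxy remains open, since only one such step can be read. Also open, from the compounds shown here alone, is how a chloro or a nitrile at the same place on the benzyl group, or an amine in place of the methoxy, would behave.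

No measurement at hand gives a reason for either step.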